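Swapping a Sulfur Link for an Oxygen Link

The compounds below may be only part of what the source reports. "The series", "measured", "known", "first", "only" and "open" are said of these compounds alone.

Measured so far:
compound 1 `Cc1cc(-c2ccc(F)cc2)c(S(C)(=O)=O)cc1C(=O)N=C(N)N` — 36 nM
compound 2 `CCCSc1cc(C)c(C(=O)N=C(N)N)cc1S(C)(=O)=O` — 6.8 nM
compound 3 `Cc1cc(Sc2ccccc2Cl)c(S(C)(=O)=O)cc1C(=O)N=C(N)N` — 14 nM

All three were tested in a functional assay for inhibition of sodium/hydrogen exchanger (Oryctolagus cuniculus); a higher number here means a weaker inhibitor, a lower number a stronger inhibitor. Compound 3 sits second highest of the three numbers: the step of a 2.1-fold higher number from compound 2 to compound 3 (0.31 log units; beyond the scatter) and the step of a 2.6-fold lower number from compound 1 to compound 3 (0.41 log units; beyond the scatter) place it between its two neighbours, both steps modest.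

Compound 4 `Cc1cc(Oc2ccc(Cl)cc2)c(S(C)(=O)=O)cc1C(=O)N=C(N)N` keeps the shared core and differs from compound 3 in one place: 4-chlorophenoxy in place of (2-chlorophenyl)sulfanyl on an aromatic carbon. Among the compounds with values here, no measured step exchanges the sulfur link for an oxygen one or shifts the chlorine on the ring, so the only guidance comes from the two modest steps around compound 3 in this assay. On that basis the expected step of a 1.1-fold higher number from compound 3 to compound 4 (0.03 log units; within the scatter) is small and may not exceed the scatter. The estimated value for compound 4 in this assay is 15 nM, with a range from 6 nM to 40 nM.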

Compound 4, half-maximal inhibitory concentration: 13 nM
Estimate against measurement, compound 4: 1.2-fold (0.06 log units) above; low and high end bracket the measured number.
By their numbers in this assay, from the lowest: compounds 2, 4 and 3 (each within the scatter of the next, the first and the last beyond it); then compound 1.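

In this assay this position tolerates a new linking atom and a moved chlorine together, with a 1.1-fold lower number from compound 3 to compound 4 (0.03 log units; within the scatter). The 4-chlorophenoxy group also stays close to propylsulfanyl, with a 1.9-fold higher number from compound 2 to compound 4 (0.28 log units; within the scatter) and, against 4-fluorophenyl, gives a 2.8-fold lower number from compound 1 to compound 4 (0.44 log units; beyond the scatter). No supporting evidence is available to explain these numbers.

The link and the chlorine position could each matter alone and offset one another, since neither 2-chlorophenoxy nor (4-chlorophenyl)sulfanyl appears among these compounds. As far as these compounds go, how an amine or a carboxylic acid would fare at this position also remains open.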